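The source may hold more compounds than are shown below. What is called first, only, known or untested is meant among the compounds shown, and "the series" means these compounds.

Measured in a functional assay on EOL1 cells (Homo sapiens) for inhibition, read by fluorescence, with a stated time of 72 h (on this read-out lower numbers stand for stronger inhibition of growth and higher numbers for weaker inhibition of growth), so far:
- compound 1 `COc1ccc(Cn2cnc3c(Nc4cccc(Cl)c4)nc(N[C@H]4CC[C@H](N)CC4)nc32)cc1` gives 530 nM
- compound 2 `CCCCCCn1cnc2c(Nc3cccc(Cl)c3)nc(N[C@H]3CC[C@H](N)CC3)nc21` gives 310 nM
- compound 3 `CCCCn1cnc2c(Nc3cccc(Cl)c3)nc(N[C@H]3CC[C@H](N)CC3)nc21` gives 160 nM

Compound 3 lies within the scatter of one neighbour, a 1.9-fold lower number from compound 2 to compound 3 (0.29 log units; within the scatter), and clear of the other, a 3.3-fold lower number from compound 1 to compound 3 (0.52 log units; beyond the scatter). Next is compound 4 `N[C@H]1CC[C@H](Nc2nc(Nc3cccc(Cl)c3)c3ncn(Cc4ccccc4)c3n2)CC1`, with the change (phenyl in place of propyl on a saturated chain carbon bound to an aromatic nitrogen). This is phenyl in place of propyl on a saturated chain carbon bound to an aromatic nitrogen, also readable as butyl to benzyl. The closest measured precedent is the modest step above, propyl in place of 4-methoxyphenyl, which runs the opposite way. Pentyl in place of 4-methoxyphenyl gave only a 1.7-fold lower number from compound 1 to compound 2 (0.23 log units; within the scatter). A modest rise in the number is therefore expected in this assay. The expected step is a 1.9-fold higher number from compound 3 to compound 4 (0.27 log units; within the scatter). For compound 4 the estimate is 300 nM, with an expected range of 130 nM to 650 nM.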

Compound 4, concentration for 50% growth inhibition: 380 nM
Estimate against measurement, compound 4: 1.3-fold (0.10 log units) below, within the range that was stated.
By their numbers in this assay, from the lowest: compounds 3, 2, 4 and 1 (each within the scatter of the next, the first and the last beyond it).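

Working notes on the saturated chain carbon bound to an aromatic nitrogen: in this assay the butyl of compound 3 stays ahead of benzyl, with a 2.4-fold higher number from compound 3 to compound 4 (0.38 log units; beyond the scatter) as a modest step. Benzyl does not separate from the substituents of the other two compounds, with a 1.2-fold higher number from compound 2 to compound 4 (0.09 log units; within the scatter) and a 1.4-fold lower number from compound 1 to compound 4 (0.14 log units; within the scatter) both within the scatter. Hydrogen in place of methoxy on an aromatic carbon therefore leaves no readable difference here.

Open, going by these compounds, is whether an ethyl chain, or a benzyl carrying an amine or a carboxylic acid, would hold this level. No measurement at hand explains these steps.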